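Swapping cyclohexyl for 3-cyanophenyl in a glycosylated hydrazone

A few compounds are considered here, and "the series" means these few. Any claim that something is new, unique, unknown or untested is made for them only; others in the source may bear on it.

Of the compounds shown here, three sharing one core have been measured in a functional assay on MDA-MB-231 cells (Homo sapiens) for inhibition, read by MTT assay, with a stated time of 24 h, tested at 100 uM; a higher number here means more inhibition at the concentration tested (going by the name of the read-out), a lower number less inhibition. Compound 1 `O=C(N/N=C/c1cccc(Cl)c1)c1ccc(O[C@@H]2O[C@H](CO)[C@@H](O)[C@H](O)[C@H]2O)cc1` gives 5.02%. Compound 2 `CC(C)/C=N/NC(=O)c1ccc(O[C@@H]2O[C@H](CO)[C@@H](O)[C@H](O)[C@H]2O)cc1` gives 1.7%, and compound 3 `O=C(N/N=C/C1CCCCC1)c1ccc(O[C@@H]2O[C@H](CO)[C@@H](O)[C@H](O)[C@H]2O)cc1` gives 0.88%. Compound 3 has the lowest of the three numbers, but the steps of a number 4.1 percentage points lower from compound 1 to compound 3 (within the scatter) and a number 0.8 percentage points lower from compound 2 to compound 3 (within the scatter) are both within the scatter, as is a number 3.3 percentage points lower from compound 1 to compound 2 (within the scatter), so the three compounds cannot be told apart on these numbers.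

Compound 4 `N#Cc1cccc(/C=N/NC(=O)c2ccc(O[C@@H]3O[C@H](CO)[C@@H](O)[C@H](O)[C@H]3O)cc2)c1` has not yet been measured. It differs from compound 3 in one place: 3-cyanophenyl in place of cyclohexyl on a carbon with a double bond to nitrogen. The step that bears most on this change is the one from an aromatic ring to cyclohexyl, a number 4.1 percentage points lower from compound 1 to compound 3 (within the scatter), which runs the other way; reversing it would suggest a few points higher, still within the scatter. Compound 4 is therefore expected to show a number 3.1 percentage points higher from compound 3 to compound 4 (within the scatter). The value estimated for compound 4 in this assay is 4%, with a range from 0% to 12%.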

Compound 4, a percentage reported as inhibition, at one concentration (the size of the read-out at that concentration, not a potency): 6.17%
Compound 4: middle estimate off by 2.2 percentage points, on the low side; low and high end bracket the measured number.
By their numbers in this assay, from the lowest: compounds 3, 2, 1 and 4 (each within the scatter of the next).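

In this assay the two steps of a number 5.3 percentage points higher from compound 3 to compound 4 (within the scatter) and a number 4.5 percentage points higher from compound 2 to compound 4 (within the scatter) show that even putting 3-cyanophenyl, an aromatic ring carrying a nitrile, in place of either saturated group gives no change that can be read at this position. The step of a number 1.2 percentage points higher from compound 1 to compound 4 (within the scatter) adds that cyano and chloro on the aromatic ring cannot be told apart here, so all four groups tried on this carbon leave the number near the floor of the read-out. No measured property is available to account for these numbers.

From the compounds shown here alone, whether an amine or a carboxylic acid on the aromatic ring, or a longer chain on this carbon, would move the number clear of the scatter remains open. A single tested concentration also says nothing about potency.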